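A few compounds are considered here, and "the series" means these few. Any claim that something is new, unique, unknown or untested is made for them only; others in the source may bear on it.

Compound 1 (`CCN(CC)Cc1ccc2nc(NC(=O)N/N=C/c3cn(Cc4ccc(C(C)(C)C)cc4)c4ccccc34)sc2c1`) gives 1710 nM
Compound 2 (`CCN(CC)Cc1ccc2nc(NC(=O)N/N=C/c3cn(Cc4ccc(C)cc4)c4ccccc34)sc2c1`) gives 1510 nM
Compound 3 (`Cc1ccc(Cn2cc(/C=N/NC(=O)Nc3nc4ccc(CN(C)C)cc4s3)c3ccccc32)cc1`) has not yet been measured

These values come from a functional assay on A549 cells (Homo sapiens) for cytotoxicity, read by MTT assay, with a stated time of 72 h; on this read-out lower numbers stand for stronger inhibition and higher numbers for weaker inhibition. Within the data shown here, only two numbers are available, and compound 2, at 1510 nM, stands level with compound 1 within the scatter. Compound 3 differs from compound 2 at one place, with dimethylamino in place of diethylamino on a saturated chain carbon bound to an aromatic carbon.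

Among the measured compounds shown here, only one measured step is available, and it does not touch this amine group. It replaces tert-butyl with methyl on an aromatic carbon and amounts to a 1.1-fold lower number from compound 1 to compound 2 (0.05 log units; within the scatter). It shows that one substituent change left the number within the scatter, but it offers only indirect guidance on the present change. No direction can be drawn from these data, so no shift beyond the scatter is expected in this assay. The estimated step is a 1.0-fold lower number from compound 2 to compound 3 (0.00 log units; within the scatter), a small one. For compound 3 the expected value is 1500 nM (estimated range 700 nM to 3200 nM) .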

Compound 3, half-maximal inhibitory concentration: 1600 nM
Compound 3: the middle estimate sits 1.1-fold (0.03 log units) below what was measured, within the range that was stated.
By their numbers in this assay, from the lowest: compounds 2, 3 and 1 (each within the scatter of the next).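

In this assay, among these compounds, the first measured step at this position, dimethylamino in place of diethylamino on a saturated chain carbon bound to an aromatic carbon, gives a 1.1-fold higher number from compound 2 to compound 3 (0.03 log units; within the scatter). The earlier step concerned only the tert-butyl and methyl groups on an aromatic carbon, whereas this one shows that the amine can go from 5 heavy atoms to 3 while the number stays within the scatter of that of compound 2. No supporting measurement bears on this result.

With only diethylamino and dimethylamino shown at this place, it remains open whether a cyclic amine such as morpholine or piperidine, or a carboxylic acid, would keep the number in the same range. It is also open whether any amine is needed here at all, as the compounds shown include no case in which a plain methyl group or a hydroxymethyl group stands in place of the whole (dimethylamino)methyl group.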